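Second Fluoro on the Aryl Ring of Compound 2

The source may report more compounds than this note shows. Statements on the series, on what has been measured and on what is new or still open speak of the compounds shown alone.

Measured compounds:
Compound 1 `O=C1NC(=O)/C(=C\c2ccc(OCC(=O)N3N=C(c4ccccc4)CC3c3ccc(C(F)(F)F)cc3)cc2)S1`: 16000 nM
Compound 2 `O=C1NC(=O)/C(=C\c2ccc(OCC(=O)N3N=C(c4ccccc4)CC3c3ccc(F)cc3)cc2)S1`: 26000 nM

Both compounds were tested in an assay on cells for inhibition of histone deacetylase 8 (Homo sapiens), read by fluorescence, with a stated time of 30 min; a lower number here means a stronger inhibitor, a higher number a weaker inhibitor. Compound 1 gives 16000 nM, and compound 2 gives 26000 nM. Of the two numbers, compound 2 has the higher one, but the step of a 1.6-fold higher number from compound 1 to compound 2 (0.21 log units; within the scatter) lies within the scatter, so the two compounds cannot be separated on these data.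

Compound 3 `O=C1NC(=O)/C(=C\c2ccc(OCC(=O)N3N=C(c4ccccc4)CC3c3ccc(F)cc3F)cc2)S1` has not yet been measured. It differs from compound 2 by fluoro in place of hydrogen on an aromatic carbon. Among the compounds with values here, the only measured step that bears on this change is the exchange on the same aryl ring, a 1.6-fold higher number from compound 1 to compound 2 (0.21 log units; within the scatter), which was within the scatter. A second fluoro of this kind is therefore not expected to move the number in this assay beyond the scatter in either direction. The expectation for compound 3 is 22000 nM, with a range of 8000 nM to 60000 nM. This estimate amounts to a 1.2-fold lower number from compound 2 to compound 3 (0.07 log units; within the scatter), a step expected to fall within the scatter.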

Compound 3, half-maximal inhibitory concentration: 34000 nM
Beside the measured number, compound 3's estimate is 1.5-fold (0.19 log units) below it; measured number inside the range.
By their numbers in this assay, from the lowest: compounds 1, 2 and 3 (each within the scatter of the next, the first and the last beyond it).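

In this assay the change from 4-fluorophenyl to 2,4-difluorophenyl, which puts a fluoro ortho to a large group, gives a 1.3-fold higher number from compound 2 to compound 3 (0.12 log units; within the scatter) and so the data do not separate this fluoro from the hydrogen it replaces. Within the data shown here, the exchange of 4-(trifluoromethyl)phenyl for 2,4-difluorophenyl gives a 2.1-fold higher number from compound 1 to compound 3 (0.33 log units; beyond the scatter) and is the first step in this set to pass the scatter, although only modestly, so compound 1 and compound 3 are the only pair whose numbers can be told apart. No measurement is at hand that could explain either step.

What remains open is whether a methoxy group, an amine or a carboxylic acid on this aryl ring would move the number further than the fluoro and trifluoromethyl groups shown here. Also open, from the compounds shown here alone, is whether the same added fluoro would give a similarly small step on the aryl ring of compound 1, which carries trifluoromethyl in place of the first fluoro.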